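Can a 2-hydroxyphenyl group restore activity to compound 4?

The source may report more compounds than this note shows. Statements on the series, on what has been measured and on what is new or still open speak of the compounds shown alone.

In a functional assay on SMMC-7721 cells (Homo sapiens) for antiproliferative activity, read by MTT assay, with a stated time of 72 h (a higher number here means a weaker inhibitor, a lower number a stronger inhibitor), compound 3 (`O=C(N/N=C/c1ccccn1)c1cccc(S(=O)(=O)N2CCOCC2)c1`) reaches only a limit, > 100000 nM. Compound 2 (`O=C(N/N=C/c1ccco1)c1cccc(S(=O)(=O)N2CCOCC2)c1`) also reaches only a limit, > 100000 nM. Among the measured compounds shown here, the one measured step is a step that the two limits leave unreadable from compound 2 to compound 3, so it offers no size to carry forward. Compound 4 (`O=C(N/N=C/c1ccccc1O)c1cccc(S(=O)(=O)N2CCOCC2)c1`) has 2-hydroxyphenyl in place of pyridin-2-yl on a carbon with a double bond to nitrogen. The best guide is compound 1 (`C/C(=N\NC(=O)c1cccc(S(=O)(=O)N2CCOCC2)c1)c1ccccc1O`), which also bears 2-hydroxyphenyl on such a carbon and gives a true number, 1370 nM. A large move towards stronger inhibition in this assay is therefore expected, the estimated step being an at least 33-fold lower number from compound 3 to compound 4 (1.52 log units; beyond the scatter). Compound 4 is estimated at 3000 nM, with an expected range of 500 nM to 30000 nM.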

Compound 4, half-maximal inhibitory concentration: 12100 nM
Compound 4: middle estimate off by 4.0-fold (0.61 log units), on the low side; low and high end bracket the measured number.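

In this assay on this carbon, 2-hydroxyphenyl gives a readable number where the two other rings reached only a limit: replacing pyridin-2-yl gives an at least 8.2-fold lower number from compound 3 to compound 4 (0.91 log units; beyond the scatter) and replacing furan-2-yl gives an at least 8.2-fold lower number from compound 2 to compound 4 (0.91 log units; beyond the scatter). Measurable activity therefore does not need the methyl group that compound 1 carries on this carbon. Both steps are minimum sizes only, because compound 2 and compound 3 stand at a limit of the assay: the limit of > 100000 nM in this assay, at which 2 of the 4 values shown sit.

As far as these compounds go, it stays open whether the hydroxyl group itself is what counts, which a plain phenyl or a 2-methoxyphenyl group on this carbon could test.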